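The source may hold more compounds than are shown below. What is called first, only, known or untested is meant among the compounds shown, and "the series" means these compounds.

Working notes on the series in a functional assay on SNB-75 cells (Homo sapiens) for inhibition, read by sulforhodamine B assay, with a stated time of 48 h, tested at 100 uM; on this read-out lower numbers stand for a stronger effect and higher numbers for a weaker effect at the one concentration tested. Compound 1 `O=C(Nc1cccc(-n2cc(-c3ccncc3)c(-c3cc(O)cc(Cl)c3)n2)c1)Nc1ccc(Cl)c(Cl)c1` gives -15% in this assay. Compound 2 `COc1cc(Cl)cc(-c2nn(-c3cccc(NC(=O)Nc4cc(C(F)(F)F)cc(C(F)(F)F)c4)c3)cc2-c2ccncc2)c1` gives -58% in this assay. Compound 3 `COc1cc(Cl)cc(-c2nn(-c3cccc(NC(=O)Nc4ccc(Cl)c(Cl)c4)c3)cc2-c2ccncc2)c1` gives -3% in this assay, the highest of the three numbers; its nearest neighbour is compound 1 and the furthest is compound 2. For the measured compounds named here, the only single-point step on record, a number 12 percentage points higher from compound 1 to compound 3 (beyond the scatter), concerns methyl in place of hydrogen on an oxygen on an aromatic ring and does not touch the carbonyl end of the molecule.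

Compound 4 `COc1cc(Cl)cc(-c2nn(-c3cccc(NC(=O)c4cccc(C(F)(F)F)c4)c3)cc2-c2ccncc2)c1` is not yet measured. It differs from compound 3 in 3-(trifluoromethyl)phenyl in place of (3,4-dichlorophenyl)amino on a carbonyl carbon: the (3,4-dichlorophenyl)amino leaves and 3-(trifluoromethyl)phenyl enters, on a carbonyl carbon whose other neighbour is an amide-type nitrogen. Going by the values given here, no measured step bears directly on this change. Among the compounds with values here, compound 2 and compound 3 differ elsewhere and no step between them is recorded; their two values show only that the compound carrying trifluoromethyl groups returned the lower number. Given the loss of the amide-type nitrogen together with the entry of one trifluoromethyl group, a small step to a lower number, a number 9 percentage points lower from compound 3 to compound 4 (within the scatter), is expected, with wide uncertainty. For compound 4 in this assay the estimate is -12%, from -45% to 10%.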

Compound 4, a percentage reported as activity, at one concentration (the size of the read-out at that concentration, not a potency): 49%
For compound 4 the middle estimate is 61 percentage points below the measured one; measured number outside the range, above it.
By their numbers in this assay, from the lowest: compound 2; then compound 1; then compound 3; then compound 4.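

In this assay, the carbonyl end of the molecule responds far more than the oxygen on the aromatic ring: the step printed here as large is a number 52 percentage points higher from compound 3 to compound 4 (beyond the scatter), while the one printed as modest is a number 12 percentage points higher from compound 1 to compound 3 (beyond the scatter). For the compounds shown here, compound 4 is also the only one of the four compounds with a number above zero, so this single change on a carbonyl carbon carries the series from negative to positive values at the one concentration tested. The step swaps (3,4-dichlorophenyl)amino for 3-(trifluoromethyl)phenyl, which removes a nitrogen and changes the ring substituents together, and no measurement at hand accounts for the result.

The shown compounds leave open which part of the swap matters, since 3,4-dichlorophenyl set directly on the carbonyl carbon, (3-(trifluoromethyl)phenyl)amino on that carbon, or a methylene in place of the amide-type nitrogen would each separate the loss of the nitrogen from the change of ring substituents. From the compounds shown here alone, it is also open whether the step holds with a hydroxy group in place of the methoxy group, as in compound 1.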